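Swapping an amide ring for a cyclic sulfonamide

A few compounds are considered here, and "the series" means these few. Any claim that something is new, unique, unknown or untested is made for them only; others in the source may bear on it.

Of the compounds shown here, two sharing one core have been measured in an ADME assay on microsomes from liver (Homo sapiens) for metabolic stability, read by LC-MS, using NADPH, with a stated time of 45 min, tested at 0.5 uM; a higher number here means faster removal of the compound, a lower number slower removal. Compound 1, `O=C(CCCSc1nc2cc(Cl)ccc2o1)N1CCCC1`, gives 3.4 mL/min/g, the higher of the two numbers. Compound 2, `CS(=O)(=O)C1CCN(C(=O)CCSc2nc3cc(Cl)ccc3o2)CC1`, gives 0.5 mL/min/g in this assay, a gap from compound 1 that lies beyond the usual scatter, so compound 1 is removed faster than compound 2.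

The next compound, compound 3, `O=S1(=O)CCCN1CCCSc1nc2cc(Cl)ccc2o1`, has not yet been measured. Compared with compound 1 it differs in one place: a group of 7 heavy atoms (3 carbon, 1 nitrogen, 2 oxygen, 1 sulfur; one five-membered non-aromatic ring with 2 hetero atoms) in place of a group of 7 heavy atoms (5 carbon, 1 nitrogen, 1 oxygen; one five-membered non-aromatic ring with 1 hetero atom), on a saturated chain carbon, three bonds along the chain from a sulfur. The chain from the sulfur is kept, and the ring at its end changes from one carrying a carbonyl to one carrying a sulfur with two oxygens.

Within the data shown here, no measured pair shows exactly this change, so the direction can only be guessed from the two numbers known. Because compound 2 gives 0.5 mL/min/g with a sulfur bearing two oxygens, and compound 1 gives 3.4 mL/min/g without one, a modest fall in this assay is expected, near the edge of the scatter. The estimated step from compound 1 to compound 3 is a 2.1-fold lower number from compound 1 to compound 3 (0.33 log units; beyond the scatter). For compound 3 the expected value is 1.6 mL/min/g, within the range 0.6 mL/min/g to 4 mL/min/g.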

Compound 3, intrinsic clearance in a liver preparation (reported as CLH), per the amount of preparation that the assay uses: 4.7 mL/min/g
Compound 3: middle estimate off by 2.9-fold (0.47 log units), on the low side; measured number above the stated range.
By their numbers in this assay, from the lowest: compound 2; then compounds 1 and 3 (each within the scatter of the next).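

In this assay, replacing the (pyrrolidin-1-yl)carbonyl group with the five-membered ring holding a sulfur with two oxygens gives a 1.4-fold higher number from compound 1 to compound 3 (0.14 log units; within the scatter), so the two compounds cannot be told apart in this read-out. Among these compounds, this is the first direct reading of a single change at this position, on a saturated chain carbon, three bonds along the chain from a sulfur, and it shows that this swap, which keeps the count of 7 heavy atoms but adds a second double bond outside aromatic rings and a second hydrogen-bond acceptor, leaves the number within the usual scatter. No available measurement offers an explanation for this result.

Compound 2 differs from compound 1 in more than one place, so the compounds shown do not say which of its differences goes with its number, and the sulfur with two oxygens cannot be credited with it on this evidence. As far as these compounds go, it also remains open whether a different end group on this chain, such as an amine or a carboxylic acid, or a longer chain, would give a step beyond the scatter.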